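The source may report more compounds than this note shows. Statements on the series, on what has been measured and on what is new or still open speak of the compounds shown alone.

Measured so far in a functional assay on the whole organism (Tail, strain ICR) with Mus musculus as the target, in the tail flick test, with a stated time of 90 min, at a dose of 25 umol/kg by the oral route; on this read-out lower numbers stand for a weaker effect and higher numbers for a stronger effect at the one dose given:

compound 1, `O=C(CN(c1nc(Cl)nc2[nH]cnc12)C1CC1)N[C@@H](CCC(=O)OCc1ccccc1)C(=O)OCc1ccccc1`, gives 50%
compound 2, `CSCC[C@H](NC(=O)CN(c1ncnc2c1ncn2C1CCCCO1)C1CC1)C(=O)OCc1ccccc1`, gives 42.7%
compound 3, `O=C(O)CC[C@H](NC(=O)CN(c1nc(Cl)nc2[nH]cnc12)C1CC1)C(=O)O`, gives 44.7%

Compound 3 stands second highest of the three numbers in this assay. Its nearest neighbour is compound 2, whose value of 42.7% lies within the usual scatter of the value of compound 3, and the furthest is compound 1, whose value of 50% also lies within that scatter. On these numbers, then, the three compounds cannot be told apart, and none of them can be called stronger or weaker than another.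

Compound 4, `NCCCC[C@H](NC(=O)CN(c1nc(Cl)nc2[nH]cnc12)C1CC1)C(=O)O`, has not yet been measured. It differs from compound 3 in one place: 2-aminoethyl in place of carboxy on a saturated chain carbon, three bonds along the chain from an amide-type nitrogen and a carbonyl carbon. For the measured compounds named here, no pair of measured compounds shows this same change, so there is no measured step to compare it with. In the absence of such a step, the expectation is a small move, within the scatter, in this assay; the estimated step is a number 0.3 percentage points higher from compound 3 to compound 4 (within the scatter), which is expected to be no change beyond the scatter. Compound 4 is therefore estimated at 45%, with a likely range from 25% to 65%.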

Compound 4, a percentage reported as activity, at one dose (the size of the read-out at that dose, not a potency): 28.8%
Beside the measured number, compound 4's estimate is 16.2 percentage points above it, and the stated range covers the measured number.
By their numbers in this assay, from the lowest: compound 4; then compounds 2, 3 and 1 (each within the scatter of the next).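

In this assay, the group on this saturated chain carbon, three bonds along the chain from an amide-type nitrogen and a carbonyl carbon, proves to matter: replacing 2-carboxyethyl with 4-aminobutyl gives a number 15.9 percentage points lower from compound 3 to compound 4 (beyond the scatter). For the compounds shown here, this is the first single change that can be read as a step, since the earlier compounds offered no pair differing in one place, and it shows that the effect at this one dose is sensitive to what this side chain carries. Nothing available explains why the number falls with this change.

This one step alters the end group and the chain together, so it cannot tell whether the loss of the carboxylic acid, the arrival of the amine or the different chain counts most. As far as these compounds go, a plain butyl chain with no amine at its end, or a longer chain ending in a carboxylic acid, at the same position on the same core, remains open and could separate these parts of the change.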